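The compounds below may be only part of what the source reports. "The series", "measured", "known", "first", "only" and "open" are said of these compounds alone.

Working notes on the series.

Compound 3 `N=C(NCCCc1c[nH]cn1)NCCC(c1ccc(C(F)(F)F)cc1)c1ccccn1` carries a 4-(trifluoromethyl)phenyl on the chain carbon. Among the measured compounds shown here, in a functional assay on ileum for antagonist activity at histamine H1 receptor (Cavia porcellus) (a lower number here means tighter binding, a higher number weaker binding), compound 3 gives 282 nM, the highest of the three numbers measured so far. Its nearest neighbour is compound 1 `N=C(NCCCc1c[nH]cn1)NCCCC(c1ccccc1)c1ccccn1`, which in this assay gives 251 nM, a gap within the scatter; the two are not connected by a single-point step, since compound 3 also differs in chain length. The furthest is compound 2 `N=C(NCCCc1c[nH]cn1)NCCCC(c1ccc(F)cc1)c1ccccn1`, which in this assay gives 46.8 nM, a gap beyond the scatter.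

Compound 4 `N=C(NCCCc1c[nH]cn1)NCCC(c1ccc(Cl)c(Cl)c1)c1ccccn1` follows from compound 3 by 3,4-dichlorophenyl in place of 4-(trifluoromethyl)phenyl on a saturated chain carbon bound to an aromatic carbon and a saturated chain carbon. For the measured compounds named here, the only measured single-point step in the set concerns a halogen added to the same phenyl ring: a 5.4-fold lower number from compound 1 to compound 2 (0.73 log units; beyond the scatter). Going by the values given here, that step is the nearest guide, though it bears on a single fluorine rather than two chlorines, and no step in the set reports a trifluoromethyl being removed.

Among the compounds with values here, on this guide, compound 4 is expected to move toward a lower number in this assay, with a step of about a 2.4-fold lower number from compound 3 to compound 4 (0.37 log units; beyond the scatter), held back from the full size of the fluoro step because a 5.4-fold lower number from compound 1 to compound 2 (0.73 log units; beyond the scatter) is the only halogen-for-hydrogen step in the set and it starts from a different compound. The estimate for compound 4 is 120 nM, with a range from 35 nM to 400 nM.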

Compound 4, dissociation constant: 79.4 nM
Beside the measured number, compound 4's estimate is 1.5-fold (0.18 log units) above it; the measured number falls inside the stated range.
By their numbers in this assay, from the lowest: compounds 2 and 4 (each within the scatter of the next); then compounds 1 and 3 (each within the scatter of the next).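

Working notes, continued.

On the saturated chain carbon bound to an aromatic carbon and a saturated chain carbon, 3,4-dichlorophenyl in place of 4-(trifluoromethyl)phenyl gives a 3.6-fold lower number from compound 3 to compound 4 (0.55 log units; beyond the scatter) in this assay, the first single-place step read with the chain of compound 3, and it shows that the number at this chain length responds to the aryl group on that carbon. Among the compounds shown here, the only earlier single-place step, a 5.4-fold lower number from compound 1 to compound 2 (0.73 log units; beyond the scatter), concerned fluoro in place of hydrogen on the chain of compound 1, so the set now holds two changes on this phenyl ring, each ending at a lower number and each beyond the scatter, with no single-place step going against that direction. No measurement in the set explains why the number moves with this exchange.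

From the compounds shown here alone, the exchange removes trifluoromethyl and brings in two chlorines in a single step, so the share of each remains open, and a 4-chlorophenyl or 4-methoxyphenyl group on the same carbon would help to separate them. Also open, going by these compounds, is whether 3,4-dichlorophenyl gives a step of the same direction on the longer chain of compound 1.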